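Dichlorophenoxy to Fluorophenoxy on a Shared Core

This account rests on a few compounds, and the source may have more. Where it says the series, first, only, none or still open, it means among the compounds named here.

Compound 1 `Nc1cc(N)c2nc(-c3ccccc3)c(Oc3ccc(Cl)c(Cl)c3)nc2c1`: < 100000 nM
Compound 2 `CCOC(=O)[C@H](CCC(=O)O)NC(=O)c1ccc(CNc2nc3cc(N)cc(N)c3nc2-c2ccccc2)cc1`: < 100000 nM

Both compounds were tested in a functional assay on DU-145 cells (Homo sapiens) for inhibition, read by sulforhodamine B assay, with a stated time of 48 h; a higher number here means a weaker inhibitor of growth, a lower number a stronger inhibitor of growth. Compound 1 gives < 100000 nM, which is a limit of the assay rather than a number. Compound 2 gives < 100000 nM, also only a limit. As far as these compounds go, with the limit of < 100000 nM in this assay, at which 2 of the 2 values shown sit, compound 1 has no definite place on the scale: it inhibits growth within the tested range, but how strongly is unknown. Compound 3 `Nc1cc(N)c2nc(-c3ccccc3)c(Oc3ccc(F)cc3)nc2c1` differs from compound 1 by 4-fluorophenyl in place of 3,4-dichlorophenyl on an oxygen on an aromatic ring. For the measured compounds named here, no measured step shows what this change does. The expected shift is a step that the limit leaves unreadable from compound 1 to compound 3, none beyond the scatter. Compound 3 is estimated at 20000 nM, between 3000 nM and 100000 nM.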

Compound 3, concentration for total growth inhibition: 87100 nM
Compound 3: the middle estimate sits 4.4-fold (0.64 log units) below what was measured, and the stated range covers the measured number.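

No size can be read for the change from compound 1 to compound 3, because compound 1 has only a limit and not a number: the limit of < 100000 nM in this assay, at which 2 of the 3 values shown sit.

The compounds shown leave open whether 4-fluorophenyl in place of 3,4-dichlorophenyl strengthens or weakens growth inhibition in this assay.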